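One Aromatic Ring Swapped, Exposure Yet to Be Measured

The source may hold more compounds than are shown below. What is called first, only, known or untested is meant among the compounds shown, and "the series" means these compounds.

In an ADME assay on the whole organism (plasma, strain 129/SvEvBrd x C57BL/6) for pharmacokinetics, with Mus musculus as the target, at a dose of 10 mg/kg by the oral route (on this read-out higher numbers stand for higher exposure at the dose given and lower numbers for lower exposure), compound 1 `CC(=O)N/N=C(\C)c1nc([C@@H](O)[C@H](O)[C@H](O)CO)c[nH]1` reaches 1030 ng.h/mL and compound 2 `OC[C@@H](O)[C@@H](O)[C@H](O)c1c[nH]c(C(F)(F)C(F)(F)F)n1` reaches 3060 ng.h/mL on the same scale. Compound 3 `Cc1nc(-c2nc([C@@H](O)[C@H](O)[C@H](O)CO)c[nH]2)cs1` reaches 1970 ng.h/mL there, which lies within the usual scatter of both other numbers, so it cannot be ranked against either.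

Compound 4 `Cn1cnc(-c2nc([C@@H](O)[C@H](O)[C@H](O)CO)c[nH]2)c1` has not been measured yet. It carries 1-methyl-1H-imidazol-4-yl in place of 2-methyl-1,3-thiazol-4-yl on an aromatic carbon and the rest of the structure stays the same. For the measured compounds named here, no two measured compounds differ in a single place, so the data offer no direct guide to this swap. The nearest reference is compound 3 at 1970 ng.h/mL on this scale, and no step beyond the scatter is expected from it. The estimated step of a 1.2-fold lower number from compound 3 to compound 4 (0.09 log units; within the scatter) is small and leans slightly downward. For compound 4 the estimated value is 1600 ng.h/mL with an expected range from 650 ng.h/mL to 3900 ng.h/mL across repeat measurements.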

Compound 4, area under the concentration-time curve: 698 ng.h/mL
Compound 4: the middle estimate sits 2.3-fold (0.36 log units) above what was measured; low and high end bracket the measured number.
By their numbers in this assay, from the lowest: compounds 4, 1, 3 and 2 (each within the scatter of the next, the first and the last beyond it).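

In this assay, replacing 2-methyl-1,3-thiazol-4-yl with 1-methyl-1H-imidazol-4-yl gives a 2.8-fold lower number from compound 3 to compound 4 (0.45 log units; beyond the scatter), the first change in a single place among these compounds and one that lies beyond the scatter. The read-out at this aromatic carbon, between two ring nitrogen atoms, therefore depends on which ring sits there, although both groups have the same counts of heavy atoms, hydrogen-bond donors and hydrogen-bond acceptors and carry no net charge. Nothing available here explains why the number falls.

A single step cannot show how other rings would behave at this position. As far as these compounds go, it remains open whether a phenyl group or a pyridyl group would give a number closer to that of compound 3 or to that of compound 4.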